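The compounds below may be only part of what the source reports. "The series", "measured", "known", "first", "only" and "open" are said of these compounds alone.

The compounds measured so far:
compound 1 `CC/N=C(/NC#N)NCCCCn1nc(-c2ccccc2)ccc1=O`, which in a functional assay on the whole organism with Rattus norvegicus as the target (on this read-out lower numbers stand for an effect already at smaller amounts and higher numbers for an effect only at larger amounts of compound), gives 60.7 mg/kg;
compound 2 `CC/N=C(\S)NCCCn1nc(-c2ccccc2)ccc1=O`, which in this assay gives 88.2 mg/kg;
compound 3 `NC(=O)SCCCCCN1NC=CC=C1c1ccccc1`, which in this assay gives 18.3 mg/kg.

Compound 2 stands at the highest of these three numbers. Compound 1 lies within the usual scatter of compound 2, so the two cannot be told apart on this read-out. Compound 3 stands at a lower number, beyond the scatter, and so is the one of the three that shows its effect at clearly smaller amounts than compound 2.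

Compound 4 `C/N=C(\S)NCCCCn1nc(-c2ccccc2)ccc1=O` has not yet been measured. It differs from compound 2 in this way: a group of 6 heavy atoms (3 carbon, 2 nitrogen, 1 sulfur; no ring) in place of a group of 6 heavy atoms (3 carbon, 2 nitrogen, 1 sulfur; no ring), on a saturated chain carbon, three bonds along the chain from an aromatic nitrogen. The atoms are the same in both compounds and are only joined differently.

Among the measured compounds shown here, no step between two measured compounds shows what such a rearrangement does. For the measured compounds named here, compound 1 and compound 2 differ in more than one place, and compound 3 is built differently again, so nothing among the measured compounds traces this change. With so little to go on, the step in this assay is expected to be small, a 1.2-fold lower number from compound 2 to compound 4 (0.07 log units; within the scatter), in no particular direction and not beyond the scatter. Compound 4 is therefore estimated to give about 75 mg/kg, within a range from 35 mg/kg to 160 mg/kg.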

Compound 4, dose for half-maximal effect: 17.3 mg/kg
The estimate for compound 4 lay 4.3-fold (0.64 log units) above the measured number; the measured number lies below the stated range.
By their numbers in this assay, from the lowest: compounds 4 and 3 (each within the scatter of the next); then compounds 1 and 2 (each within the scatter of the next).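

In this assay, the step of a 5.1-fold lower number from compound 2 to compound 4 (0.71 log units; beyond the scatter) shows that this position is sensitive even when no atom is gained or lost: on a saturated chain carbon, three bonds along the chain from an aromatic nitrogen, one group of 6 heavy atoms replaces another made of the same atoms, and the number moves beyond the scatter. The counts of double bonds, hydrogen-bond donors and hydrogen-bond acceptors are the same for both groups, so those counts alone do not capture this difference. A second step of a 3.5-fold lower number from compound 1 to compound 4 (0.55 log units; beyond the scatter) also lies beyond the scatter and shows that replacing one group with another on an amine nitrogen changes the number as well, and nothing available explains why either step occurs.

Since the atoms are only joined differently in compound 2 and compound 4, these two compounds cannot show which part of the rearrangement matters most. Going by these compounds, what a longer chain would do here remains open, as does the effect of a simple amine or a carboxylic acid in place of the group at the end of that chain.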